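Replacing the Fluorophenyl Arm of a Compound at the Limit

A few compounds are considered here, and "the series" means these few. Any claim that something is new, unique, unknown or untested is made for them only; others in the source may bear on it.

Compound 1 `Oc1ccccc1-c1cc(-c2cccc(F)c2)cc(-c2ccccc2O)n1` is tested in a functional assay on HeLa cells (Homo sapiens) for inhibition; on this read-out higher numbers stand for weaker inhibition and lower numbers for stronger inhibition. In this assay compound 1 gives only a limit, > 50000 nM, not a number. Compound 2 `Oc1cccc(-c2cc(-c3cccc(F)c3)cc(-c3ccccc3O)n2)c1` carries a 3-hydroxyphenyl in place of one 2-hydroxyphenyl; in this assay compound 2 also gives a limit, > 50000 nM. Compound 3 `Oc1ccc(-c2cc(-c3cccc(F)c3)cc(-c3ccccc3O)n2)cc1` carries a 4-hydroxyphenyl in that place; in this assay compound 3 likewise gives a limit, > 50000 nM. The steps a step that the two limits leave unreadable from compound 1 to compound 2, a step that the two limits leave unreadable from compound 1 to compound 3 and a step that the two limits leave unreadable from compound 2 to compound 3 stay unreadable because the limit of > 50000 nM in this assay, at which 3 of the 3 values shown sit, holds every value shown.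

Compound 4 `Oc1ccccc1-c1cc(-c2ccccc2C(F)(F)F)cc(-c2ccccc2O)n1` differs from compound 1 by 2-(trifluoromethyl)phenyl in place of 3-fluorophenyl on an aromatic carbon. Going by the values given here, none of the measured steps touches this position: all three alter a hydroxyphenyl arm, and none has a readable size. The data thus give no sign of inhibition appearing beyond the scatter. Compound 4 is therefore expected to remain at the limit, with an estimate of 50000 nM between 20000 nM and 200000 nM. The expected step is a number no higher from compound 1 to compound 4 (the limit leaves the size open).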

Compound 4, half-maximal inhibitory concentration: 5800 nM
Compound 4: the middle estimate sits 8.6-fold (0.94 log units) above what was measured; the whole stated range lies above it.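

Changing the arm opposite the ring nitrogen brings the series off its limit: in this assay, 2-(trifluoromethyl)phenyl in place of 3-fluorophenyl gives an at least 8.6-fold lower number from compound 1 to compound 4 (0.93 log units; beyond the scatter). This position therefore responds to change, something the swaps among the hydroxyphenyl arms could not reveal. Those earlier steps cannot be read, because the other compounds all stop at one value: the limit of > 50000 nM in this assay, at which 3 of the 4 values shown sit.

The full size of the gain stays unknown, and a single step cannot tell whether the trifluoromethyl group itself or its placement on the phenyl ring matters, since 3-(trifluoromethyl)phenyl and 2-fluorophenyl are not among the compounds shown. Also open, on these data alone, is how this arm would respond to other groups, such as an amine or a carboxylic acid, and whether moving a hydroxyl on the compound 4 scaffold would now have a readable effect.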